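The compounds below may be only part of what the source reports. "The series", "measured", "known", "first", "only" and "open" are said of these compounds alone.

Measured so far in a physicochemical assay for lipophilicity, read by HPLC, measured as octanol-water partition; on this read-out lower numbers stand for lower lipophilicity and higher numbers for higher lipophilicity:
compound 1, `O=C1O[C@@H](CO)CN1c1ccc(-n2cc(-c3ccccn3)cn2)c(F)c1`, gives 1.67
compound 2, `CN(CCC#N)C[C@H]1CN(c2ccc(-n3cc(-c4ccccn4)cn3)c(F)c2)C(=O)O1`, gives 1.9
compound 3, `CC(=O)OC[C@H]1CN(c2ccc(-n3cc(-c4ccccn4)cn3)c(F)c2)C(=O)O1`, gives 2.09

Compound 3 holds the highest of the three numbers in this assay: a number 0.42 log units higher from compound 1 to compound 3 (beyond the scatter), and a number 0.19 log units higher from compound 2 to compound 3 (within the scatter). Compound 4, `O=C1O[C@@H](Cn2ccnc2)CN1c1ccc(-n2cc(-c3ccccn3)cn2)c(F)c1`, differs from compound 3 in one place: 1H-imidazol-1-yl in place of acetoxy on a saturated chain carbon bound to a saturated ring carbon. Both measured steps end at compound 3 and therefore bear on this change. Of the two, only the acetyl step, a number 0.42 log units higher from compound 1 to compound 3 (beyond the scatter), went beyond the scatter; the amine-to-acetoxy step stayed within it. Because compound 3 sits above compound 1 by a number 0.42 log units higher from compound 1 to compound 3 (beyond the scatter) and compound 4 gives up the acetoxy group, the step of a number 0.29 log units lower from compound 3 to compound 4 (within the scatter) is expected to run downward, probably a modest one. Compound 4 is therefore estimated at 1.8, ranging from 1.4 to 2.3.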

Compound 4, partition coefficient: 1.73
Compound 4: the middle estimate sits 0.07 log units above what was measured, within the range that was stated.
By their numbers in this assay, from the lowest: compounds 1, 4, 2 and 3 (each within the scatter of the next, the first and the last beyond it).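

On the saturated chain carbon, 1H-imidazol-1-yl brings the only aromatic ring placed there among these compounds, and in this assay replacing acetoxy with it gives a number 0.36 log units lower from compound 3 to compound 4 (beyond the scatter) as a modest change. Against the other two groups, the ring's effect cannot be told from the scatter: the (2-cyanoethyl)(methyl)amino comparison gives a number 0.17 log units lower from compound 2 to compound 4 (within the scatter) and the hydroxy comparison gives a number 0.06 log units higher from compound 1 to compound 4 (within the scatter) on this read-out. Nothing measured here explains these steps. Going by these compounds, whether a triazole ring or a carboxylic acid on this carbon would fall closer to compound 4 or compound 3 stays open.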